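The source may hold more compounds than are shown below. What is called first, only, known or untested is meant among the compounds shown, and "the series" means these compounds.

Compound 1 `CCC(C(=O)N1CCN(c2cccc(F)c2)CC1)N1C(=O)CCC1=O`: 0%
Compound 2 `CCC(C(=O)N1CCN(c2cccc(Cl)c2)CC1)N1C(=O)CCC1=O`: 25%

For the measured compounds named here, in a functional assay on the whole organism (strain Swiss) with Mus musculus as the target, in the maximal electroshock model, with a stated time of 2 h, at a dose of 300 mg/kg by the intraperitoneal route (a lower number here means a weaker effect, a higher number a stronger effect of the compound at the dose given), compound 2 stands highest of the two numbers measured, with compound 1 as its only neighbour and the step of a number 25 percentage points higher from compound 1 to compound 2 (beyond the scatter) separating them. Compound 3 `CCC(C(=O)N1CCN(c2ccc(Cl)cc2)CC1)N1C(=O)CCC1=O` differs from compound 2 by 4-chlorophenyl in place of 3-chlorophenyl on an amine nitrogen in a ring. Going by the values given here, no measured step bears directly on this change: the one step known, a number 25 percentage points higher from compound 1 to compound 2 (beyond the scatter), exchanged one halogen for another rather than moving it. For compound 3 the expected step is therefore a number 5 percentage points higher from compound 2 to compound 3 (within the scatter), not beyond the scatter. Compound 3 is estimated at 30%, within a range from 0% to 60%.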

Compound 3, a percentage reported as activity, at one dose (the size of the read-out at that dose, not a potency): 25%
Compound 3: middle estimate off by 5 percentage points, on the high side, and the stated range covers the measured number.
By their numbers in this assay, from the lowest: compound 1; then compounds 2 and 3 (each within the scatter of the next).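

In this assay the chlorine's placement on the phenyl ring shows no effect, with no change at the digits printed from compound 2 to compound 3 (within the scatter), so 4-chlorophenyl and 3-chlorophenyl cannot be told apart at this position. The step of a number 25 percentage points higher from compound 1 to compound 3 (beyond the scatter) shows that the gain over the 3-fluorophenyl compound is not tied to a single chlorine placement among these compounds. Nothing available explains this result. Still open, from the compounds shown here alone, is whether 4-fluorophenyl would stay with compound 1 or join compounds 2 and 3, and how a bromine or a methoxy group on the phenyl ring would read out.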